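The source may hold more compounds than are shown below. What is called first, only, known or untested is meant among the compounds shown, and "the series" means these compounds.

Compound 1 `COc1cc(O)cc(CCc2ccccc2)c1` and compound 2 `COc1cccc(CCc2cc(O)cc(OC)c2)c1` share one core. In a functional assay on cells (Neutrophil, Homo sapiens) for inhibition, read by spectrophotometry, with a stated time of 5 min (on this read-out lower numbers stand for stronger inhibition and higher numbers for weaker inhibition), compound 1 gives 6500 nM, and compound 2 gives 6500 nM; the step of no change at the digits printed from compound 1 to compound 2 (within the scatter) puts a methoxy in place of hydrogen on an aromatic carbon. Compound 3 `COc1cc(CCc2cccc(O)c2)cc(O)c1Cc1ccc(O)cc1` carries a 4-hydroxybenzyl group on the same core. In this assay compound 3 gives 2200 nM, the lowest of the three numbers, and its gap to compound 1 and to compound 2 lies beyond the scatter.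

Compound 4 `COc1cc(CCc2cccc(O)c2)c(Cc2ccc(O)cc2)c(O)c1Cc1ccc(O)cc1` differs from compound 3 in one place: 4-hydroxybenzyl in place of hydrogen on an aromatic carbon. Among the compounds with values here, no measured step repeats this exact change. Within the data shown here, the single measured step, no change at the digits printed from compound 1 to compound 2 (within the scatter), concerns a methoxy rather than a 4-hydroxybenzyl group and stays within the scatter, so it bears on compound 4 only loosely. The comparison of compound 3 with compound 1 and compound 2 shows that the compound bearing a 4-hydroxybenzyl group gives the lower number, although those compounds differ in more than one place. On that basis a second 4-hydroxybenzyl group is expected to lower the number modestly or to leave it within the scatter; the estimated step is a 1.5-fold lower number from compound 3 to compound 4 (0.17 log units; within the scatter). Compound 4 is thus expected to give about 1500 nM, within a range from 500 nM to 4500 nM.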

Compound 4, half-maximal inhibitory concentration: 1100 nM
Compound 4: middle estimate off by 1.4-fold (0.13 log units), on the high side; the measured number falls inside the stated range.
By their numbers in this assay, from the lowest: compounds 4 and 3 (each within the scatter of the next); then compounds 1 and 2 (each within the scatter of the next).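

In this assay, within the data shown here, the new comparison gives a 2.0-fold lower number from compound 3 to compound 4 (0.30 log units; within the scatter) and is the first in which a 4-hydroxybenzyl group is the only difference between two compounds, since the earlier contrast of compound 3 with compound 1 and compound 2 involved more than one place. It shows that this aromatic carbon, ortho to the 2-(3-hydroxyphenyl)ethyl group and to the hydroxy group, can carry a second 4-hydroxybenzyl group without moving the number beyond the scatter, so this single addition brings no clear gain or loss on this read-out. Nothing measured here offers a reason for this result.

The compounds shown leave open whether the hydroxy group on the added 4-hydroxybenzyl matters, which a plain benzyl group at the same carbon could test. They also leave open how an amine, a carboxylic acid or a longer chain ending in the same 4-hydroxyphenyl ring would behave at this place, and so how much change this position accepts before the number moves beyond the scatter.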